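Propyl Amide Analogue of Compound 3: Another Limit Expected

The source may report more compounds than this note shows. Statements on the series, on what has been measured and on what is new or still open speak of the compounds shown alone.

Compound 1 `C=CC1=C(C(=O)NCCC)C(c2ccc(F)cc2)OC1`: > 100000 nM
Compound 2 `C=CC1=C(C(=O)Nc2ccccc2)C(c2ccc(OC)cc2)OC1`: > 100000 nM
Compound 3 `C=CC1=C(C(=O)NCCCCC)C(c2ccc(OC)cc2)OC1`: > 100000 nM

Each of these values is a limit of a functional assay on SW480 cells (Homo sapiens) for cytotoxicity, read by MTT assay, with a stated time of 24 h (on this read-out lower numbers stand for stronger inhibition and higher numbers for weaker inhibition), rather than a number. Compound 3 stands at the limit of > 100000 nM in this assay, at which 3 of the 3 values shown sit; this is a limit, not a measured value. Compound 1 and compound 2 give the same limit. For the measured compounds named here, the only measured step, a step that the two limits leave unreadable from compound 2 to compound 3, has limits at both ends and its size cannot be read.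

Compound 4 `C=CC1=C(C(=O)NCCC)C(c2ccc(OC)cc2)OC1` differs from compound 3 by hydrogen in place of ethyl on a saturated chain carbon, three bonds along the chain from an amide-type nitrogen. Going by the values given here, no measured step bears on this change, and nothing in the three values argues for a move away from the limit. Compound 4 is therefore expected to show 150000 nM in this assay, within 60000 nM to 400000 nM, most probably again as a limit. The estimated step from compound 3 to compound 4 is a step that the limit leaves unreadable from compound 3 to compound 4, no change beyond the scatter.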

Compound 4, half-maximal inhibitory concentration: > 100000 nM
Compound 4: a limit, no number; the forecaster's own chance of this, stated with the estimate: 85%; the middle value does not contradict the limit.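

Compound 4 also gives only a limit, so its steps from compound 1, compound 2 and compound 3 cannot be read in this assay: the limit of > 100000 nM in this assay, at which 4 of the 4 values shown sit.

The compounds shown leave open whether changing either substituent alters cytotoxicity at all.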